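This account rests on a few compounds, and the source may have more. Where it says the series, first, only, none or still open, it means among the compounds named here.

Working notes on the cytotoxicity series. For the measured compounds named here, in an ADME assay on Vero cells (Chlorocebus sabaeus) for cytotoxicity, read by MTT assay, with a stated time of 72 h (a lower number here means that less compound is tolerated, a higher number that more compound is tolerated), compound 2 `Clc1ccc([C@@H]2C[C@@H]3Cc4ccc5ccccc5c4N2O3)cc1` gives 287000 nM, the only full number among the three measured compounds. Compound 1 `Fc1ccc([C@@H]2C[C@@H]3Cc4ccc5ccccc5c4N2O3)cc1` reaches only the limit of the assay at > 300000 nM. Compound 3 `Clc1cccc([C@@H]2C[C@@H]3Cc4ccc5ccccc5c4N2O3)c1` likewise stops at the limit of > 300000 nM. Two of the three results thus sit at the ceiling (the limit of > 300000 nM in this assay, at which 2 of the 3 values shown sit), and compound 2 stands effectively alongside them rather than apart. The step of an at least 1.0-fold lower number from compound 1 to compound 2 (0.01 log units; that floor lies within the scatter) shows nothing beyond the scatter, and the step of an at least 1.0-fold higher number from compound 2 to compound 3 (0.01 log units; that floor lies within the scatter) is equally flat. The step that the two limits leave unreadable from compound 1 to compound 3 cannot be read, as both ends are limits.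

Compound 4 `Cc1cccc([C@@H]2C[C@@H]3Cc4ccc5ccccc5c4N2O3)c1` is the next member to be measured in this assay. Relative to compound 2 the change is 3-methylphenyl in place of 4-chlorophenyl on a saturated ring carbon. The measured step that bears on this is an at least 1.0-fold higher number from compound 2 to compound 3 (0.01 log units; that floor lies within the scatter), an exchange of one aryl group for another on a saturated ring carbon that produced no readable movement. The step of a 1.0-fold higher number from compound 2 to compound 4 (0.02 log units; within the scatter) is therefore expected to show no movement beyond the scatter. For compound 4 the estimate in this assay is 300000 nM, within a range from 150000 nM to 600000 nM, with a real chance that only a limit is reported.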

Compound 4, half-maximal cytotoxic concentration: > 300000 nM
Compound 4 ended at the assay's limit (the forecaster's own chance of this, stated with the estimate: 60%); the middle value sits exactly at the limit.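

In this assay, for the compounds shown here, the exchange on the saturated ring carbon next to the ring nitrogen gives an at least 1.0-fold higher number from compound 2 to compound 4 (0.01 log units; that floor lies within the scatter), so the first aryl group without a halogen, 3-methylphenyl, leaves the reading where the halogen-bearing aryl groups stand. The aryl position has thus now taken a carbon-only substituent as well as chloro and fluoro with no readable movement, although the steps from compound 3 to compound 4 and from compound 1 to compound 4 cannot be read, as both ends of each are limits. The flat picture therefore rests mainly on limits and gives no graded comparison within the series, and the single full number, that of compound 2, stays the only fixed point: the limit of > 300000 nM in this assay, at which 3 of the 4 values shown sit.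

From the compounds shown here alone, how far compound 1, compound 3 and compound 4 lie beyond that limit stays open, so any differences among them remain hidden. Also open, going by these compounds, is whether the tolerance holds with an amine, a carboxylic acid or a longer chain on the aryl ring, or with a group other than an aryl ring at this saturated ring carbon.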